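The compounds below may be only part of what the source reports. "The series", "measured", "known", "first", "only" and "open" are said of these compounds alone.

Measured so far:
Compound 1 `COc1ccc2c(c1)/C(=C/c1c(-c3ccncc3)nc3sccn13)C(=O)N2C`: 85300 nM
Compound 2 `COc1cc2c(cc1C)NC(=O)/C2=C/c1c(OC)nc2sc(C)cn12`: 91700 nM
Compound 3 `O=C1Nc2ccccc2C1=Cc1c(-c2ccncc2)nc2sccn12`: 78300 nM

All three numbers come from a functional assay on cells (Melanoma cell) for cytotoxicity against Melanoma cell line (Homo sapiens), read by sulforhodamine B assay, with a stated time of 48 h; a lower number here means a stronger inhibitor of growth, a higher number a weaker inhibitor of growth. In this test, compound 2 gives 91700 nM and stands level with the other two compounds, since its value lies within the usual scatter of both. The data therefore separate none of these three compounds from compound 2.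

The next compound to be tested is compound 4 `COc1ccc2c(c1)/C(=C\c1c(OC)nc3sc(C)cn13)C(=O)N2`. The change from compound 2 is small: hydrogen in place of methyl on an aromatic carbon. In words, it is hydrogen in place of methyl on an aromatic carbon.

Within the data shown here, no two measured compounds differ in just one place, so this assay offers no direct measure of this change. Among the measured compounds shown here, the only guide is indirect. Compound 1 at 85300 nM and compound 3 at 78300 nM both differ from compound 2 in more than one place, yet both remain within the scatter of it. A single swap of this size is therefore expected to produce no shift beyond the scatter, in either direction.

The expected change is a 1.1-fold lower number from compound 2 to compound 4 (0.05 log units; within the scatter), an estimate that stays within the scatter. The estimated value for compound 4 is 82000 nM. The expected range runs from 45000 nM to 100000 nM.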

Compound 4, concentration for total growth inhibition: 67700 nM
For compound 4 the middle estimate is 1.2-fold (0.08 log units) above the measured one, and the stated range covers the measured number.
By their numbers in this assay, from the lowest: compounds 4, 3, 1 and 2 (each within the scatter of the next).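

Among these compounds, the swap of hydrogen for methyl gives the first direct reading at this position, which is an aromatic carbon of the six-membered aromatic ring, ortho to a methoxy group. In this assay the swap gives a 1.4-fold lower number from compound 2 to compound 4 (0.13 log units; within the scatter) and so separates the two compounds no more than repeated measurements of one compound might. The earlier comparisons could only hint at this, since each of those compounds differs from compound 2 in more than one place, whereas this pair shows that the methyl can leave this carbon with no readable gain or loss in growth inhibition, and nothing measured here offers an explanation for the size of the step.

On these data alone, what stays open is whether this carbon tolerates any group or whether only these two small substituents have so far looked alike: an amine, a carboxylic acid, a chlorine atom or a longer chain such as propyl could still move the number beyond the scatter. The result also comes from one pair in a single cell test, so it leaves open whether the same swap would behave in the same way with other groups elsewhere on the shared core.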